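Fluoro substitution on the core of compound 1

The source may hold more compounds than are shown below. What is called first, only, known or untested is meant among the compounds shown, and "the series" means these compounds.

Compound 1 `CN1CCC[C@H]1COc1cccnc1` sets the reference point for the series: in an assay on membranes from brain for displacement of a labelled ligand from Neuronal acetylcholine receptor; alpha4/beta2 (Rattus norvegicus) (on this read-out higher numbers stand for weaker inhibition and lower numbers for stronger inhibition), compound 1 gives 0.15 nM, the lowest of the three numbers recorded. Compound 2 `CN1CCC[C@H]1COc1cccnc1[N+](=O)[O-]` gives 9000 nM in this assay and compound 3 `Cc1ccncc1OC[C@@H]1CCCN1C` gives 4.12 nM. Both substitutions on the aromatic carbons of the core of compound 1 weakened binding: a 60000-fold higher number from compound 1 to compound 2 (4.78 log units; beyond the scatter), and a 27-fold higher number from compound 1 to compound 3 (1.44 log units; beyond the scatter).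

Compound 4 `CN1CCC[C@H]1COc1cncc(F)c1` is the next step. Among the measured compounds shown here, the change from compound 1 is fluoro in place of hydrogen on an aromatic carbon; the entering group is small and sits two atoms from the ring nitrogen, meta to the group of 8 heavy atoms, a different position from the one substituted in compound 2 and compound 3.

The measured steps bear only indirectly. The nitro step in compound 2 and the methyl step in compound 3 were both large and both upward, but at another position and with larger groups than fluoro. For a single fluorine at this position, a small upward step in this assay is expected, beyond the scatter but far short of those seen: a 3.3-fold higher number from compound 1 to compound 4 (0.52 log units; beyond the scatter) is the estimated change.

Compound 4 is therefore expected to give about 0.5 nM in this assay, within a range of 0.1 nM to 3 nM.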

Compound 4, inhibition constant: 0.69 nM
Compound 4: middle estimate off by 1.4-fold (0.14 log units), on the low side; the range from low to high includes it.
By their numbers in this assay, from the lowest: compound 1; then compound 4; then compound 3; then compound 2.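

Working notes on the fluoro step: in this assay, fluoro in place of hydrogen on an aromatic carbon, two atoms from the ring nitrogen and meta to a group of 8 heavy atoms, gives a modest weakening that still lies beyond the usual scatter (a 4.6-fold higher number from compound 1 to compound 4 (0.66 log units; beyond the scatter)). Among the compounds shown here, this is the first reading at this position, and it shows that a substituent here need not bring a large loss of binding, although the change does not leave binding intact. The earlier steps (a 60000-fold higher number from compound 1 to compound 2 (4.78 log units; beyond the scatter); a 27-fold higher number from compound 1 to compound 3 (1.44 log units; beyond the scatter)) involve other groups at another position, so the gap between them and the fluoro step cannot be assigned to either the group or the position, and no available data explain the weakening.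

On these data alone, it remains open whether a chloro, methyl or amine group at this same position would also give a modest step or a large one. For the compounds shown here, it is equally open how fluoro itself would fare on the aromatic carbon carrying the nitro group in compound 2 or the one carrying the methyl group in compound 3.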